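The source may report more compounds than this note shows. Statements on the series, on what has been measured and on what is new or still open speak of the compounds shown alone.

Measured so far in a functional assay on BT-474 cells (Homo sapiens) for inhibition, read by MTT assay, with a stated time of 5 days; on this read-out lower numbers stand for stronger inhibition and higher numbers for weaker inhibition:

compound 1 `Cc1cc(Nc2nc(NCc3ccc(F)cc3F)nc3[nH]ncc23)n[nH]1`: 3220 nM
compound 2 `Cc1cc(Nc2nc(NCc3ccc(F)cc3F)nc3c2cnn3C2CCCCC2)n[nH]1`: 6230 nM

Working notes. In this assay compound 2 gives 6230 nM and sits within the scatter of compound 1, so with only these two numbers it holds no distinct rank in the series. The next compound to be read is compound 3 `Cc1cc(Nc2nc(NCc3ccc(F)cc3F)nc3c2cnn3C(C)C)n[nH]1`, which keeps the shared core and the rest of compound 2 and changes one group: isopropyl in place of cyclohexyl on an aromatic nitrogen. In words, this is isopropyl in place of cyclohexyl on an aromatic nitrogen.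

Among the compounds with values here, only one measured step bears on this nitrogen, namely a 1.9-fold higher number from compound 1 to compound 2 (0.29 log units; within the scatter). Hydrogen and cyclohexyl on this nitrogen therefore gave numbers that cannot be told apart, and isopropyl has fewer heavy atoms than cyclohexyl but more than hydrogen. Within the data shown here, no compound with a small alkyl group here has been measured, so this rests on a single step. No shift beyond the scatter is expected in this assay. The expected change is a 1.4-fold lower number from compound 2 to compound 3 (0.16 log units; within the scatter). For compound 3 the estimated value is 4300 nM, with an expected range of 1900 nM to 9500 nM.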

Compound 3, half-maximal inhibitory concentration: 17300 nM
Compound 3: middle estimate off by 4.0-fold (0.60 log units), on the low side, outside the stated range (above it).
By their numbers in this assay, from the lowest: compounds 1 and 2 (each within the scatter of the next); then compound 3.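

In this assay this nitrogen is not indifferent to its substituent: isopropyl in place of cyclohexyl gives a 2.8-fold higher number from compound 2 to compound 3 (0.44 log units; beyond the scatter) and isopropyl in place of hydrogen gives a 5.4-fold higher number from compound 1 to compound 3 (0.73 log units; beyond the scatter) in a modest step, which makes compound 3 the weakest of the three. The earlier step showed only that hydrogen and cyclohexyl could not be told apart, and the new steps show that this does not extend to every group here, since isopropyl has fewer heavy atoms than cyclohexyl and more than hydrogen, yet compound 3 does not fall alongside compound 1 and compound 2, so the numbers do not follow heavy-atom count in one direction. Nothing available accounts for this result.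

The compounds shown leave open whether the higher number belongs to isopropyl alone or to small alkyl groups on this nitrogen more widely. A methyl, a cyclopentyl or a longer chain such as n-butyl at the same nitrogen would show whether the hydrogen and cyclohexyl results are the exceptions or compound 3 is.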